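Methyl Gives Way to Methoxy in Compound 4

The compounds below may be only part of what the source reports. "The series", "measured", "known", "first", "only" and "open" are said of these compounds alone.

Of the compounds shown here, three built on a shared core have been measured so far. In a functional assay on HepG2 cells (Homo sapiens) for antiproliferative activity, read by MTT assay (on this read-out lower numbers stand for stronger inhibition and higher numbers for weaker inhibition), compound 1 (`Clc1ccc(Nc2nccc(-c3ccc(Cl)cc3Cl)n2)c(Cl)c1`) stands at 8080 nM and compound 2 (`COc1ccc(-c2ccnc(Nc3ccc(Cl)cc3)n2)cc1`) at 4500 nM while compound 3 (`Cc1cccc(Nc2nccc(-c3ccc(Cl)cc3Cl)n2)c1`) reads 13200 nM on the same scale. Compound 3 therefore stands on the weak side of this small set. Its number cannot be told apart from that of compound 1 within the scatter, whereas the number of compound 2 is lower by more than the scatter.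

The next compound to be tested is compound 4 (`COc1cccc(Nc2nccc(-c3ccc(Cl)cc3Cl)n2)c1`), which carries methoxy in place of methyl on an aromatic carbon, meta to a large group (methoxy in place of methyl on an aromatic carbon). Among the compounds with values here, no measured pair in the set isolates this swap, so there is no direct precedent for it. The expectation rests only on the narrow spread of the set, which runs from compound 2 at 4500 nM to compound 3 at 13200 nM with no sharp jump. What is expected is a 1.3-fold lower number from compound 3 to compound 4 (0.12 log units; within the scatter) in this assay and such a step would stay within the scatter. For compound 4 the estimate is 10000 nM with an expected range from 4500 nM to 22000 nM around it.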

Compound 4, half-maximal inhibitory concentration: 96900 nM
Beside the measured number, compound 4's estimate is 9.7-fold (0.99 log units) below it, outside the stated range (above it).
By their numbers in this assay, from the lowest: compounds 2, 1 and 3 (each within the scatter of the next, the first and the last beyond it); then compound 4.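

In this assay the swap of methyl for methoxy on this aromatic carbon, meta to a large group, gives a 7.3-fold higher number from compound 3 to compound 4 (0.87 log units; beyond the scatter) and so offers the first view of a single change in the set, one that moves toward weaker inhibition. Compounds 1, 2 and 3 could not show this, as no two of them differ in one place, and their narrow spread gave no sign that this position could respond so strongly to a change of a single group. Nothing measured here bears on the reason for this loss. What the compounds shown leave open is whether another group on this carbon, such as an amine, a hydroxyl or a fluorine, would read closer to compound 3 or further from it, and whether a longer chain such as ethoxy would extend the step seen with methoxy. Within the data shown here, with only one pair isolating this swap, it also remains open whether the same change made elsewhere on the shared core would move the number in the same direction.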